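The source may hold more compounds than are shown below. What is called first, only, known or untested is meant among the compounds shown, and "the series" means these compounds.

Series notes. In a functional assay, with a stated time of 20 min (a lower number here means a stronger inhibitor, a higher number a weaker inhibitor), compound 1 `CCOC(=O)c1cnn(-c2nc(-c3ccccc3Cl)c(C#N)c(=O)n2C)c1N` gives 78 ug/mL, the highest of the three numbers, though within the scatter of both compound 3 `CSc1nc(-c2ccco2)c(C#N)c(=O)n1C` at 68 ug/mL and compound 2 `Cn1c(NN)nc(-c2ccco2)c(C#N)c1=O` at 64 ug/mL. Among the compounds with values here, the one measured step, a 1.1-fold higher number from compound 2 to compound 3 (0.03 log units; within the scatter), lies within the scatter and concerns a different part of the shared core. Compound 4 `CCOC(=O)c1cnn(-c2nc(-c3cccs3)c(C#N)c(=O)n2C)c1N` differs from compound 1 as follows: thiophen-2-yl in place of 2-chlorophenyl on an aromatic carbon. Within the data shown here, no measured pair changes the group at this place, so nothing bears directly on the step; the sole step seen shows this assay tolerating one change on the core without movement beyond the scatter. The expectation for compound 4 is therefore no step beyond the scatter, a 1.1-fold lower number from compound 1 to compound 4 (0.05 log units; within the scatter). Compound 4 is estimated at 70 ug/mL, with a range of 40 ug/mL to 140 ug/mL.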

Compound 4, half-maximal inhibitory concentration: 79 ug/mL
Estimate against measurement, compound 4: 1.1-fold (0.05 log units) below; the measured number falls inside the stated range.
By their numbers in this assay, from the lowest: compounds 2, 3, 1 and 4 (each within the scatter of the next).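

This position, ortho to a cyano group, now has a direct reading: thiophen-2-yl in place of 2-chlorophenyl gives a 1.0-fold higher number from compound 1 to compound 4 (0.01 log units; within the scatter) in this assay and so shows that these two aromatic groups cannot be told apart here. The pair changes ring size, hetero atom and chlorine together, so their separate contributions cannot be read from it. No available measurement accounts for this flat result.

Going by these compounds, whether an amine, a carboxylic acid or a longer alkyl chain at this place would move the number remains open.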